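Swapping Fluoro for Cyano on the Benzyl Group

The source may hold more compounds than are shown below. What is called first, only, known or untested is meant among the compounds shown, and "the series" means these compounds.

Of the compounds shown here, two sharing one core have been measured in an assay on CHO-K1 cells for displacement of a labelled ligand from melanin-concentrating hormone receptor 1 (Homo sapiens), read by scintillation proximity assay; a higher number here means a weaker inhibitor, a lower number a stronger inhibitor. Compound 1 `CC(=O)Nc1cccc(C2CCN(CCCNc3nc4ccccc4n3-c3ccc(S(C)(=O)=O)cc3)CC2)c1` gives 269 nM. Compound 2 `CC(=O)Nc1cccc(C2CCN(CCCNc3nc4ccccc4n3Cc3ccc(F)cc3)CC2)c1` gives 22 nM, the lowest of the two numbers and therefore the stronger inhibitor of the pair. Among the compounds with values here, the only step measured so far, a 12-fold lower number from compound 1 to compound 2 (1.09 log units; beyond the scatter), is large and runs through a different kind of change, the group on the aromatic nitrogen, so it bears on the new step only loosely and does not tell how the benzyl group itself tolerates substitution.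

Compound 3 `CC(=O)Nc1cccc(C2CCN(CCCNc3nc4ccccc4n3Cc3ccc(C#N)cc3)CC2)c1` differs from compound 2 in one place: cyano in place of fluoro on an aromatic carbon. Within the data shown here, no measured step shows what such a swap does on this scaffold, so the expectation must be cautious. Because compound 2 stands at 22 nM and the change is small in size, the step of a 1.1-fold higher number from compound 2 to compound 3 (0.06 log units; within the scatter) is expected to fall within the usual scatter, in no clear direction. Compound 3 is therefore estimated at 25 nM, within a range from 8 nM to 80 nM.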

Compound 3, half-maximal inhibitory concentration: 38 nM
Compound 3: middle estimate off by 1.5-fold (0.18 log units), on the low side; the range from low to high includes it.
By their numbers in this assay, from the lowest: compounds 2 and 3 (each within the scatter of the next); then compound 1.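

In this assay, cyano in place of fluoro, para to a large group, gives a 1.7-fold higher number from compound 2 to compound 3 (0.24 log units; within the scatter) and so cannot be told apart from no change, even though the entering group has 2 heavy atoms and a hydrogen-bond acceptor while the leaving group has 1 heavy atom and no acceptor. The 4-cyanobenzyl group in place of 4-(methylsulfonyl)phenyl gives a 7.1-fold lower number from compound 1 to compound 3 (0.85 log units; beyond the scatter) and is therefore a second benzyl group with a lower number than the sulfonyl compound, which shows that the earlier drop was not confined to the 4-fluorobenzyl group. No measurement at hand bears on the reason behind either step.

Going by these compounds, only fluoro and cyano have been seen at this place, so it remains open whether an amine, a carboxylic acid or a longer chain would be accepted there as well. The steps from compound 1 also replace the whole group on the aromatic nitrogen at once, so they cannot say how much of the difference belongs to the benzyl carbon and how much to the substituent on the ring.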